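Removing the Ethyl Group From the Aryl Ring

The source may hold more compounds than are shown below. What is called first, only, known or untested is meant among the compounds shown, and "the series" means these compounds.

Of the compounds shown here, two have been measured in an assay on isolated protein for inhibition of Rho-associated protein kinase 2 (Homo sapiens), read by a luciferase reporter; on this read-out higher numbers stand for weaker inhibition and lower numbers for stronger inhibition. Compound 1 `O=C(Nc1cc2cc[nH]c(=O)c2cc1Cl)C1CNCC1c1ccc(Cl)cc1Cl` carries a 2,4-dichlorophenyl group on a saturated ring carbon, and in this assay compound 1 gives 8 nM. Compound 2 `CCc1cccc(C2CNCC2C(=O)Nc2cc3cc[nH]c(=O)c3cc2Cl)c1` carries a 3-ethylphenyl group in that place, and in this assay compound 2 gives 4 nM. The step of a 2.0-fold lower number from compound 1 to compound 2 (0.30 log units; within the scatter) is small. Among the compounds with values here, compound 2 thus stands with the lowest of the two numbers, but its only neighbour, compound 1, lies within the usual scatter, so the two cannot be told apart.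

Compound 3 `O=C(Nc1cc2cc[nH]c(=O)c2cc1Cl)C1CNCC1c1ccccc1` is the next compound: hydrogen in place of ethyl on an aromatic carbon, leaving a plain phenyl group. Within the data shown here, only one measured step bears on this change, a 2.0-fold lower number from compound 1 to compound 2 (0.30 log units; within the scatter), which showed that exchanging one aryl group for a quite different one barely moved the number. That single step gives no sign that the number depends strongly on what sits on that ring, so the expectation for compound 3 is a step of a 2.0-fold higher number from compound 2 to compound 3 (0.30 log units; within the scatter) in this assay, a slight weakening at most and not clearly beyond the scatter. Compound 3 is expected to give 8 nM, with a range from 3 nM to 25 nM.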

Compound 3, half-maximal inhibitory concentration: 6 nM
Estimate against measurement, compound 3: 1.3-fold (0.12 log units) above; low and high end bracket the measured number.
By their numbers in this assay, from the lowest: compounds 2, 3 and 1 (each within the scatter of the next).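

In this assay, taking the ethyl group off gives a 1.5-fold higher number from compound 2 to compound 3 (0.18 log units; within the scatter), so this substituent on the aryl ring is not shown to matter for the number. Replacing the 2,4-dichlorophenyl group with plain phenyl gives a 1.3-fold lower number from compound 1 to compound 3 (0.12 log units; within the scatter), so the three aryl groups now on record cannot be told apart, and an unsubstituted ring serves as well as either substituted one on this read-out. Within the data shown here, the earlier pair showed only that one substituted ring could stand in for another, whereas this result shows that neither the ethyl group nor the chlorine atoms are needed for numbers of this size, though no information is available on why this position tolerates such changes.

The compounds shown leave open whether any group on this ring can move the number beyond the scatter, for instance an amine, a carboxylic acid or a longer chain such as propyl in place of ethyl. From the compounds shown here alone, all of this rests on this assay alone, so how the three compounds compare on any other read-out remains unknown.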